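The source may hold more compounds than are shown below. What is called first, only, known or untested is meant among the compounds shown, and "the series" means these compounds.

In a functional assay on SW-620 cells (Homo sapiens) for cytotoxicity (a higher number here means a weaker inhibitor of growth, a lower number a stronger inhibitor of growth), compound 1 (`COc1ccc(C2=C(c3ccc(SC)cc3)CC3CCCN3C2=O)cc1OC(=O)CNC(=O)OC(C)(C)C`) gives 20000 nM and compound 2 (`COc1ccc(C2=C(c3ccc(SC)cc3)CC3CCCN3C2=O)cc1OC(=O)C1CCCN1C(=O)OC(C)(C)C`) gives 10000 nM. Compound 3 (`CSc1ccc(C2=C(c3ccc(C)c(C)c3)C(=O)N3CCCC3C2)cc1`) holds the lowest of the three numbers, at 700 nM, and both other compounds lie beyond the scatter from it. The next structure, compound 4 (`CSc1ccc(C2=C(c3ccc(C)cc3)C(=O)N3CCCC3C2)cc1`), turns the 3,4-dimethylphenyl of compound 3 into 4-methylphenyl, with hydrogen in place of methyl on an aromatic carbon. Among the measured compounds shown here, only one measured step is available, a 2.0-fold lower number from compound 1 to compound 2 (0.30 log units; within the scatter), and it concerns a change on a carbonyl carbon, not on this aromatic ring. For the measured compounds named here, it therefore says nothing direct about losing this methyl, and no measured pair isolates that change. Without such evidence, no step beyond the scatter is expected in this assay. The estimate amounts to an expected 1.1-fold higher number from compound 3 to compound 4 (0.06 log units; within the scatter). Compound 4 is expected at 800 nM, with an estimated range from 250 nM to 2500 nM.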

Compound 4, concentration for 50% growth inhibition: 3000 nM
The estimate for compound 4 lay 3.8-fold (0.57 log units) below the measured number; measured number outside the range, above it.
By their numbers in this assay, from the lowest: compound 3; then compound 4; then compounds 2 and 1 (each within the scatter of the next).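

In this assay, taking one methyl off the 3,4-dimethylphenyl gives a 4.3-fold higher number from compound 3 to compound 4 (0.63 log units; beyond the scatter), a modest step but one beyond the scatter. Among the compounds shown here, the only earlier step lay on a carbonyl carbon and stayed within the scatter, whereas this one shows that a change of a single carbon, on an aromatic carbon ortho to a methyl group and meta to a large group, is enough to move the number. Nothing available explains the size or direction of this step.

Going by these compounds, it remains open whether methyl is special at this carbon or whether another group, such as chlorine, methoxy or ethyl, would serve as well or better. On these data alone, the contribution of the methyl that remains in the 4-methylphenyl is also open, and an unsubstituted phenyl or an amine in its place would address it.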